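The source may report more compounds than this note shows. Statements on the series, on what has been measured and on what is new or still open speak of the compounds shown alone.

In a functional assay on HepG2 cells (Homo sapiens) for antiproliferative activity, read by MTT assay, with a stated time of 72 h (on this read-out higher numbers stand for weaker inhibition and lower numbers for stronger inhibition), compound 1 (`CC(=O)NNC(=O)c1csc2ncc(-c3ccc(C)cc3)n12`) gives 63600 nM, compound 2 (`COc1ccc(-c2cnc3scc(C(=O)NNC(C)=O)n23)cc1`) gives 11800 nM and compound 3 (`CC(=O)NNC(=O)c1csc2ncc(-c3ccc(Br)cc3)n12`) gives 3480 nM, the lowest number of the three. Compound 4 (`CCCC(=O)NNC(=O)c1csc2ncc(-c3ccc(Br)cc3)n12`) carries one change from compound 3: ethyl in place of hydrogen on a saturated chain carbon bound to a carbonyl carbon, which turns acetyl to propylcarbonyl. The measured steps, a 5.4-fold lower number from compound 1 to compound 2 (0.73 log units; beyond the scatter), an 18-fold lower number from compound 1 to compound 3 (1.26 log units; beyond the scatter) and a 3.4-fold lower number from compound 2 to compound 3 (0.53 log units; beyond the scatter), all concern a group on an aromatic carbon, so none of them tests this chain. Within the data shown here, they show only that a single change there moved the number beyond the scatter in these compounds. In this assay, from the compounds shown here alone, no step beyond the scatter is therefore expected, though either direction remains open. The expected step is a 1.2-fold lower number from compound 3 to compound 4 (0.06 log units; within the scatter). For compound 4 the estimated value is 3000 nM, with an expected range of 1000 nM to 10000 nM.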

Compound 4, half-maximal inhibitory concentration: 33600 nM
The estimate for compound 4 lay 11-fold (1.05 log units) below the measured number, outside the stated range (above it).
By their numbers in this assay, from the lowest: compound 3; then compound 2; then compounds 4 and 1 (each within the scatter of the next).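

The saturated chain carbon bound to a carbonyl carbon proves sensitive in this assay: ethyl in place of hydrogen there gives a 9.7-fold higher number from compound 3 to compound 4 (0.98 log units; beyond the scatter), beyond the scatter and towards weaker inhibition. The acyl end therefore matters as well as the group on the aromatic carbon, although this rests on one pair carrying bromo. Nothing measured here accounts for the rise.

Open, from the compounds shown here alone, is whether a single methyl at this carbon, a longer chain or a terminal amine would give a similar rise. Also open, going by these compounds, is whether propylcarbonyl has the same effect with methyl or methoxy on the aromatic carbon.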